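The source may report more compounds than this note shows. Statements on the series, on what has been measured and on what is new or still open speak of the compounds shown alone.

Compound 1 `Cc1nc2c3ccccc3ccc2c2nc3c(ccc4ccccc43)c(-c3cccnc3)c12`: 98.2 ug/mL
Compound 2 `Cc1nc2c3ccccc3ccc2c2nc3c(ccc4ccccc43)c(-c3cccc4ccccc34)c12`: 111 ug/mL

Both were measured in a functional assay, read by spectrophotometry, with a stated time of 30 min; on this read-out higher numbers stand for weaker inhibition and lower numbers for stronger inhibition. Compound 2 stands together with compound 1, the two numbers separated only by a 1.1-fold higher number from compound 1 to compound 2 (0.05 log units; within the scatter). Compound 3 `Cc1nc2c3ccccc3ccc2c2nc3c(ccc4ccccc43)c(-c3ccccc3N)c12` differs from compound 2 by 2-aminophenyl in place of naphthalen-1-yl on an aromatic carbon. Going by the values given here, the one measured step bearing on this change, a 1.1-fold higher number from compound 1 to compound 2 (0.05 log units; within the scatter), shows that a change of the group on this carbon left the read-out essentially unmoved. Compound 3 is therefore expected to show no step beyond the scatter, a 1.1-fold lower number from compound 2 to compound 3 (0.05 log units; within the scatter), in this assay . The estimated value of compound 3 is 100 ug/mL, with a range from 50 ug/mL to 200 ug/mL.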

Compound 3, half-maximal inhibitory concentration: 95.4 ug/mL
Beside the measured number, compound 3's estimate is 1.0-fold (0.02 log units) above it; the measured number falls inside the stated range.
By their numbers in this assay, from the lowest: compounds 3, 1 and 2 (each within the scatter of the next).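

At this carbon, opposite the ring nitrogen, a third group also leaves the read-out in this assay unmoved: 2-aminophenyl gives a 1.2-fold lower number from compound 2 to compound 3 (0.07 log units; within the scatter) against naphthalen-1-yl and a 1.0-fold lower number from compound 1 to compound 3 (0.01 log units; within the scatter) against pyridin-3-yl. Even the exchange of two fused carbon rings for one ring bearing a hydrogen-bond donor stays within the scatter. No measurement at hand explains why these groups read alike. On these data alone, whether a carboxylic acid or a longer alkyl chain on this carbon would shift the number remains open. So does the effect of any change to the methyl group on the shared core.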